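A Chloro Group Returns to the Aryl Ring

The source may report more compounds than this note shows. Statements on the series, on what has been measured and on what is new or still open speak of the compounds shown alone.

Among the compounds with values here, compound 2 (`CC1(C)CCC(CN2CCN(c3ccc(C(=O)NS(=O)(=O)c4ccc(NCC5CCOCC5)c([N+](=O)[O-])c4)c(Oc4cnc5[nH]ccc5c4)c3)CC2)=C(c2ccccc2C(F)(F)F)C1`) holds the lower of the two numbers so far in a functional assay on RS4-11 cells (Homo sapiens) for inhibition, read by CCK-8 assay, with a stated time of 72 h (on this read-out lower numbers stand for stronger inhibition and higher numbers for weaker inhibition), at 18 nM. Compound 1 (`CC1(C)CCC(CN2CCN(c3ccc(C(=O)NS(=O)(=O)c4ccc(NCC5CCOCC5)c([N+](=O)[O-])c4)c(Oc4cnc5[nH]ccc5c4)c3)CC2)=C(c2ccc(Cl)cc2C(F)(F)F)C1`) stands at 74 nM. The next structure, compound 3 (`CC1(C)CCC(CN2CCN(c3ccc(C(=O)NS(=O)(=O)c4ccc(NCC5CCOCC5)c([N+](=O)[O-])c4)c(Oc4cnc5[nH]ccc5c4)c3)CC2)=C(c2ccc(C(F)(F)F)c(Cl)c2)C1`), differs from compound 2 as follows: 3-chloro-4-(trifluoromethyl)phenyl in place of 2-(trifluoromethyl)phenyl on a double-bonded ring carbon. Thus, 3-chloro-4-(trifluoromethyl)phenyl replaces 2-(trifluoromethyl)phenyl on a double-bonded ring carbon.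

Within the data shown here, only one measured step bears on this change: a 4.1-fold lower number from compound 1 to compound 2 (0.61 log units; beyond the scatter), which came with hydrogen in place of chloro on an aromatic carbon. Compound 3 regains a chloro, so a rise of similar modest size is expected, reversing a 4.1-fold lower number from compound 1 to compound 2 (0.61 log units; beyond the scatter). Among the measured compounds shown here, no measured step covers the changed place of the trifluoromethyl group, so the expectation stays wide. The expected step is a 3.3-fold higher number from compound 2 to compound 3 (0.52 log units; beyond the scatter). The estimate for compound 3 is 60 nM, with an expected range from 15 nM to 250 nM.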

Compound 3, half-maximal inhibitory concentration: 81 nM
Estimate against measurement, compound 3: 1.4-fold (0.13 log units) below; the measured number falls inside the stated range.
By their numbers in this assay, from the lowest: compound 2; then compounds 1 and 3 (each within the scatter of the next).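

In this assay, replacing 2-(trifluoromethyl)phenyl with 3-chloro-4-(trifluoromethyl)phenyl on the double-bonded ring carbon gives a 4.5-fold higher number from compound 2 to compound 3 (0.65 log units; beyond the scatter). Against the other chloro-bearing group, 4-chloro-2-(trifluoromethyl)phenyl, the same group gives a 1.1-fold higher number from compound 1 to compound 3 (0.04 log units; within the scatter), so the two arrangements of chloro and trifluoromethyl are not told apart at this position. Among the three compounds, compound 2, the only one without a chloro, stands apart from both others, and nothing measured here gives a reason for this.

Compound 3 adds a chloro and moves the trifluoromethyl group in a single change from compound 2, so the share of each in the step stays unseparated. Also open, from the compounds shown here alone, is how a fluoro, a methoxy or a nitrile in place of the chloro would read in this assay.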